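Acyl chain length in the tetrazole phenol series

The source may report more compounds than this note shows. Statements on the series, on what has been measured and on what is new or still open speak of the compounds shown alone.

Among the measured compounds shown here, compound 3 `CCc1cc(C(=O)C(C)C)c(O)cc1OCCCCCC(C)(C)c1nnn[nH]1` gives 8600 nM in an assay on isolated protein for antagonist activity at Bile acid receptor (Homo sapiens), read by HTRF, with a stated time of 30 min (a higher number here means a weaker inhibitor, a lower number a stronger inhibitor), and stands at the upper end of the three numbers so far, alongside compound 2 `CCC(=O)c1cc(CC)c(OCCCCCC(C)(C)c2nnn[nH]2)cc1O`, which gives 8500 nM; the step of a 1.0-fold higher number from compound 2 to compound 3 (0.01 log units; within the scatter), so the two cannot be ordered. Compound 1 `CCc1cc(C(C)=O)c(OC(C)c2ccccc2)cc1OCCCCCC(C)(C)c1nnn[nH]1` gives 1700 nM, a lower number beyond the scatter from compound 3, but compound 1 differs from compound 3 in more than one place, so only the two values can be set side by side.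

Compound 4 `CCCCCCC(=O)c1cc(CC)c(OCCCCCC(C)(C)c2nnn[nH]2)cc1O` carries hexyl in place of isopropyl on a carbonyl carbon. For the measured compounds named here, the only measured step that touches the acyl group is the one from compound 2 to compound 3, methyl in place of hydrogen on a saturated chain carbon bound to a carbonyl carbon and a saturated chain carbon, and it stayed within the scatter. Going by the values given here, no measured pair shows a longer chain on the carbonyl carbon, so the size of any effect of the hexyl group is unsupported by data. On that basis the step of a 1.4-fold lower number from compound 3 to compound 4 (0.16 log units; within the scatter) is expected to be small, with no direction claimed beyond the scatter. Compound 4 is therefore estimated at 6000 nM in this assay, with a range from 2000 nM to 18000 nM.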

Compound 4, half-maximal inhibitory concentration: 8400 nM
The estimate for compound 4 lay 1.4-fold (0.15 log units) below the measured number, within the range that was stated.
By their numbers in this assay, from the lowest: compound 1; then compounds 4, 2 and 3 (each within the scatter of the next).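

In this assay the acyl position now has a wider change on record: hexyl in place of isopropyl on a carbonyl carbon, taking the group from 3 to 6 heavy atoms, gives a 1.0-fold lower number from compound 3 to compound 4 (0.01 log units; within the scatter) and so no readable shift. Butyl in place of hydrogen on a saturated chain carbon, two bonds along the chain from a carbonyl carbon, gives a 1.0-fold lower number from compound 2 to compound 4 (0.01 log units; within the scatter) and likewise leaves the number in place, so compounds 2, 3 and 4 cannot be ordered, and this position has so far tolerated both branching and a longer chain without a change beyond the scatter. Nothing on hand explains this flat reading.

Going by these compounds, whether a chain longer than hexyl, a cyclohexyl group or an amine on the carbonyl carbon would move the number beyond the scatter remains open. On these data alone, compound 1 gives 1700 nM but differs from these compounds in more than one place, so which of its differences goes with that value also remains open.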